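This account rests on a few compounds, and the source may have more. Where it says the series, first, only, none or still open, it means among the compounds named here.

Compound 1 `COc1ccc(/C=C\c2cc(OC)c(OC)c(OC)c2)cc1OCc1ccc(C=O)cc1`: 41000 nM
Compound 2 `COc1ccc(/C=C\c2cc(OC)c(OC)c(OC)c2)cc1OCc1ccc(CN2CC(C(=O)O)C2)cc1`: > 50000 nM

Both compounds were tested in an ADME assay on NCM460 cells (Homo sapiens) for cytotoxicity, read by CCK-8 assay, with a stated time of 48 h; a lower number here means a stronger inhibitor, a higher number a weaker inhibitor. Compound 2 gives > 50000 nM, which is a limit of the assay and not a number.

Compound 3 `COc1ccc(/C=C\c2cc(OC)c(OC)c(OC)c2)cc1OCc1ccc(CN[C@H](C(=O)O)[C@@H](C)O)cc1` keeps the shared core and changes one group: (1-carboxy-2-hydroxypropyl)amino in place of 3-carboxyazetidin-1-yl on a saturated chain carbon bound to an aromatic carbon. Here (1-carboxy-2-hydroxypropyl)amino takes the place of 3-carboxyazetidin-1-yl on a saturated chain carbon bound to an aromatic carbon.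

Going by the values given here, only one measured step bears on this change, and only loosely: an at least 1.2-fold higher number from compound 1 to compound 2 (0.08 log units; that floor lies within the scatter). That step brought in the group that now leaves. Among the compounds with values here, no measured step exchanges one of these two groups for the other, so no step beyond the scatter is expected, and the estimated change is a step that the limit leaves unreadable from compound 2 to compound 3. Compound 3 is expected to read 55000 nM, with an estimated range of 30000 nM to 100000 nM.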

Compound 3, half-maximal inhibitory concentration: > 50000 nM
Compound 3: only a limit was reported; the forecaster's own chance of this, stated with the estimate: 75%; the middle value is on the limit's open side.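

In this assay, compound 3 gives > 50000 nM, which is a limit of the assay and not a number. Replacing the ring of 3-carboxyazetidin-1-yl with (1-carboxy-2-hydroxypropyl)amino, which has no ring and two defined stereocentres, therefore still gives a limit at this place, on a saturated chain carbon bound to an aromatic carbon, and the change from formyl gives an at least 1.2-fold higher number from compound 1 to compound 3 (0.08 log units; that floor lies within the scatter). The step between compound 2 and compound 3 cannot be read, because neither compound has a number here: the limit of > 50000 nM in this assay, at which 2 of the 3 values shown sit.

As far as these compounds go, how far either group truly lies from the formyl of compound 1 stays open, since the floor of that step does not pass the scatter. Also open, from the compounds shown here alone, is how a plain amine without a carboxylic acid, or a longer chain carrying one, would read at this place.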